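Fluoro on the pyridine ring of a thiosemicarbazone amidrazone

This account rests on a few compounds, and the source may have more. Where it says the series, first, only, none or still open, it means among the compounds named here.

Measured so far:
compound 1 `N/C(=N\NC(=S)N1CCSCC1)c1ccccn1`: 83.9%
compound 2 `N/C(=N\NC(=S)N1CCCCC1)c1ccccn1`: 85.8%
compound 3 `N/C(=N\NC(=S)N1CCCC1)c1ccccn1`: 83.9%

In a functional assay on A-375 cells (Homo sapiens) for cytotoxicity, read by MTT assay, with a stated time of 72 h, tested at 10 uM (on this read-out lower numbers stand for less inhibition of growth and higher numbers for more inhibition of growth at the one concentration tested), compound 1 gives 83.9%, level with compound 3 and together with it the lowest of the three numbers; its furthest neighbour is compound 2, with a number 1.9 percentage points higher from compound 1 to compound 2 (within the scatter). The other two steps, no change at the digits printed from compound 1 to compound 3 (within the scatter) and a number 1.9 percentage points lower from compound 2 to compound 3 (within the scatter), also stay within the scatter, so the cyclic amine on the thiocarbonyl carbon makes no visible difference here.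

Compound 4 `N/C(=N\NC(=S)N1CCSCC1)c1ccc(F)cn1` differs from compound 1 in another place: fluoro in place of hydrogen on an aromatic carbon. Among the measured compounds shown here, none of the measured steps touches that ring, so they offer no guidance on direction or size. Compound 4 is therefore expected to stay near compound 1, with a number 0.1 percentage points higher from compound 1 to compound 4 (within the scatter), giving an estimate of 84% in the range 70% to 93%.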

Compound 4, percent growth inhibition at one concentration: 70.9%
Beside the measured number, compound 4's estimate is 13.1 percentage points above it; the measured number falls inside the stated range.
By their numbers in this assay, from the lowest: compound 4; then compounds 1, 3 and 2 (each within the scatter of the next).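

In this assay, fluoro in place of hydrogen on an aromatic carbon, two atoms from the ring nitrogen and para to a large group, gives a number 13 percentage points lower from compound 1 to compound 4 (beyond the scatter), a modest step beyond the scatter. Unlike the exchanges of cyclic amine on the thiocarbonyl carbon, this change to the ring does register on this read-out. Nothing at hand bears on the reason for the step.

As far as these compounds go, whether chloro, methoxy or an amine at this position would also lower the number remains open. So does whether fluoro has the same effect on compound 2 or compound 3, which carry other cyclic amines.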